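From Compound 3 to Compound 4 in Channel Activation

The source may report more compounds than this note shows. Statements on the series, on what has been measured and on what is new or still open speak of the compounds shown alone.

In an assay on HEK293 cells for activation of Kir3.1/Kir3.2 (Homo sapiens), read by thallium flux (a higher number here means a larger maximal response, a lower number a smaller maximal response), compound 3 `Cc1cc(NC(=O)Cn2nnc(-c3cccc(C#N)c3)n2)n(C2CCCCC2)n1` gives 80%, the lowest of the three measured numbers. Compound 1 `Cc1cc(NC(=O)Cn2nnc(-c3cccc(F)c3)n2)n(C2CCCCC2)n1` gives 96%, and compound 2 `Cc1ccc(-c2nnn(CC(=O)Nc3cc(C)nn3C3CCCCC3)n2)cc1` gives 86%. The step of a number 16 percentage points lower from compound 1 to compound 3 (beyond the scatter) lies beyond the scatter, whereas a number 6 percentage points lower from compound 2 to compound 3 (within the scatter) and a number 10 percentage points lower from compound 1 to compound 2 (within the scatter) do not.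

Compound 4 `Cc1cc(NC(=O)Cn2nnc(-c3ccc(Cl)c(C)c3)n2)n(C2CCCCC2)n1` differs from compound 3 at the aromatic carbon between two ring nitrogen atoms: 4-chloro-3-methylphenyl in place of 3-cyanophenyl on an aromatic carbon

All three measured steps exchange the group on this same carbon, and none moves the maximal response far. A modest step is therefore expected for the new group, estimated as a number 6 percentage points higher from compound 3 to compound 4 (within the scatter). Compound 4 is expected to reach 86% in this assay, with a range from 72% to 100%.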

Compound 4, largest response reached (Emax), in percent of the reference or control that the assay uses: 89%
Compound 4: middle estimate off by 3 percentage points, on the low side; low and high end bracket the measured number.
By their numbers in this assay, from the lowest: compounds 3, 2, 4 and 1 (each within the scatter of the next, the first and the last beyond it).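

In this assay the 4-chloro-3-methylphenyl group, the only ring here with two substituents, sits with the singly substituted rings at this aromatic carbon, with a number 9 percentage points higher from compound 3 to compound 4 (within the scatter) and a number 3 percentage points higher from compound 2 to compound 4 (within the scatter) and also a number 7 percentage points lower from compound 1 to compound 4 (within the scatter) as its steps. A chlorine and a second substituent on the phenyl are thus compatible with a large maximal response, and compound 4 separates from none of the other three. No measurement at hand accounts for these steps. Still open, on these data alone, is how the response changes with an amine or a carboxylic acid on the phenyl. As far as these compounds go, a longer chain in place of the phenyl is equally open.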